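A few compounds are considered here, and "the series" means these few. Any claim that something is new, unique, unknown or untested is made for them only; others in the source may bear on it.

Working notes on the series. Compound 1 `C/C(=N/NC(=S)Nc1ccccc1)c1ccccn1` gives 1.4 nM in a functional assay on U-87MG ATCC cells (Homo sapiens) for cytotoxicity, read by MTT assay, with a stated time of 48 h; on this read-out higher numbers stand for weaker inhibition and lower numbers for stronger inhibition. Compound 3 `C/C(=N\NC(=S)Nc1ccccc1)c1ccccn1` gives 1.4 nM in this assay; compounds 1 and 3 differ only in configuration as drawn (the two compounds have the same atoms and bonds and differ only in configuration as drawn: 1 of 1 stereo elements differ; a double bond is drawn Z in compound 1 and E in compound 3), and the step of no change at the digits printed from compound 1 to compound 3 (within the scatter) is consistent with the fact that compounds 1 and 3 differ only in the configuration as drawn. Compound 2 `C/C(=N/NC(=S)Nc1ccccc1I)c1ccccn1` gives 6.1 nM, the step being a 4.4-fold higher number from compound 1 to compound 2 (0.64 log units; beyond the scatter) with the change (iodo in place of hydrogen on an aromatic carbon). Compound 4 `C/C(=N\NC(=S)Nc1cccc(I)c1)c1ccccn1` is not yet measured; it differs from compound 3 by iodo in place of hydrogen on an aromatic carbon, the same kind of change as from compound 1 to compound 2, though the place differs: ortho to a large group in compound 2, meta to a large group in compound 4. Because compound 3 gives 1.4 nM and the iodo step gave a 4.4-fold higher number from compound 1 to compound 2 (0.64 log units; beyond the scatter), a step of similar size is expected, a 3.2-fold higher number from compound 3 to compound 4 (0.51 log units; beyond the scatter). Compound 4 is therefore estimated at 4.5 nM, with a range from 1.5 nM to 14 nM.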

Compound 4, half-maximal inhibitory concentration: 84 nM
Compound 4: middle estimate off by 19-fold (1.27 log units), on the low side, outside the stated range (above it).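

In this assay the iodo change gives a 60-fold higher number from compound 3 to compound 4 (1.78 log units; beyond the scatter), and its size does not carry over from the earlier step: the same change on two cores in this assay, a 4.4-fold higher number (0.64 log units; beyond the scatter) from compound 1 to compound 2 and a 60-fold higher number (1.78 log units; beyond the scatter) from compound 3 to compound 4, 14-fold (1.14 log units) apart, beyond the scatter of two such steps. Both steps go to a higher number, so across these two pairs the direction carries but the size does not. The pairs differ both in where the iodo sits, meta to a large group in compound 4 and elsewhere on the ring in compound 2, and in the double bond as drawn, and they do not show which of the two goes with the gap.

Open, on these data alone, is whether iodo at each place gives the same step on both double-bond forms. Also open, as far as these compounds go, is whether another group at the place it holds in compound 4, such as chloro, methoxy or an amine, gives a step of similar size.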